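The source may report more compounds than this note shows. Statements on the series, on what has been measured and on what is new or still open speak of the compounds shown alone.

Working notes on the series: in a functional assay on HL-60 cells (Homo sapiens) for inhibition, read by MTT assay, with a stated time of 72 h (on this read-out lower numbers stand for stronger inhibition and higher numbers for weaker inhibition), compound 1 `Cc1ccc(N2CCN(C(=O)c3oc(C)nc3-c3ccccc3)CC2)c(C)c1` gives 101 nM and compound 2 `Cc1nc(-c2ccccc2)c(C(=O)N2CCN(c3cccc(C(F)(F)F)c3)CC2)o1` gives 153 nM, so compound 2 stands within the scatter of its only measured neighbour. Compound 3 `Cc1nc(-c2ccccc2)c(C(=O)N2CCN(c3ccccc3F)CC2)o1`, still unmeasured, carries 2-fluorophenyl in place of 3-(trifluoromethyl)phenyl on an amine nitrogen in a ring. Within the data shown here, the one measured step at this place is a 1.5-fold higher number from compound 1 to compound 2 (0.18 log units; within the scatter), which lies within the scatter, so no change beyond the scatter is expected in this assay. The expected step is a 1.2-fold lower number from compound 2 to compound 3 (0.07 log units; within the scatter). Compound 3 is estimated at 130 nM, with an expected range of 50 nM to 350 nM.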

Compound 3, half-maximal inhibitory concentration: 147 nM
Compound 3: the middle estimate sits 1.1-fold (0.05 log units) below what was measured; the measured number falls inside the stated range.
By their numbers in this assay, from the lowest: compounds 1, 3 and 2 (each within the scatter of the next).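

In this assay, a 1.0-fold lower number from compound 2 to compound 3 (0.02 log units; within the scatter) and a 1.5-fold higher number from compound 1 to compound 3 (0.16 log units; within the scatter) show that three differently substituted phenyl groups on the amine nitrogen give numbers within the scatter of one another. The swap to 2-fluorophenyl brings no change beyond the scatter, so this position shows no sensitivity across these three groups. No measurement bearing on a cause for this is available. Going by these compounds, whether an unsubstituted phenyl, a cyclohexyl ring or a carboxylic acid on the phenyl ring would move the number beyond the scatter remains open.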